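Fluoro in place of bromo on the shared core

A few compounds are considered here, and "the series" means these few. Any claim that something is new, unique, unknown or untested is made for them only; others in the source may bear on it.

Compound 2 (`[N-]=[N+]=N[C@H]1C[C@H](n2cc(Br)c(=O)[nH]c2=O)O[C@@H]1CO`) gives > 100 ug/mL in an ADME assay on Huh-7 cells (Homo sapiens) for cytotoxicity, read by thymidine incorporation (a higher number here means that more compound is tolerated, a lower number that less compound is tolerated), which is a limit and not a number. Compound 1 (`[N-]=[N+]=N[C@H]1C[C@H](n2cc(Cl)c(=O)[nH]c2=O)O[C@@H]1CO`) gives > 100 ug/mL, also a limit. Both compounds stand at the limit of > 100 ug/mL in this assay, at which 2 of the 2 values shown sit. Compound 3 (`[N-]=[N+]=N[C@H]1C[C@H](n2cc(F)c(=O)[nH]c2=O)O[C@@H]1CO`) differs from compound 2 by fluoro in place of bromo on an aromatic carbon. Going by the values given here, the only measured step bearing on this change is a step that the two limits leave unreadable from compound 1 to compound 2, so no size can be carried over from it. No change beyond the scatter is therefore expected in this assay, and no direction can be assigned. The expected step is a number no higher from compound 2 to compound 3 (the limit leaves the size open). Compound 3 is estimated at 100 ug/mL, with an expected range of 40 ug/mL to 200 ug/mL.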

Compound 3, half-maximal cytotoxic concentration: > 100 ug/mL
Compound 3 gave a limit, no number (the forecaster's own chance of this, stated with the estimate: 70%); the middle value lies on the limit itself.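

In this assay, going by these compounds alone, compound 1, compound 2 and compound 3 all give limits and not numbers, so no step among them can be read: the limit of > 100 ug/mL in this assay, at which 3 of the 3 values shown sit. The compounds shown leave open at what concentration any of the three turns cytotoxic, and whether chloro, bromo or fluoro then separates them.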